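A few compounds are considered here, and "the series" means these few. Any claim that something is new, unique, unknown or untested is made for them only; others in the source may bear on it.

Measured so far:
Compound 1, `Cc1ccc(C)c(-n2nncc2CN2C(=O)C3(C(C#N)=C(N)Oc4c3c3nc5ccccc5nc3c3ccccc43)c3ccccc32)c1` — in a functional assay on HCT-116 cells (Homo sapiens) for antiproliferative activity, read by MTT assay, with a stated time of 48 h (on this read-out higher numbers stand for weaker inhibition and lower numbers for stronger inhibition), compound 1 gives > 50000 nM, a limit of the assay.
Compound 2, `Cc1cc(C)cc(-n2nncc2CN2C(=O)C3(C(C#N)=C(N)Oc4c3c3nc5ccccc5nc3c3ccccc43)c3ccccc32)c1` — in this assay compound 2 gives > 50000 nM, again a limit.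
Compound 3, `Cc1ccc(C)c(-n2nncc2CN2C(=O)C3(C(C#N)=C(N)Oc4c(N)cc5nc6ccccc6nc5c43)c3ccccc32)c1` — in this assay compound 3 gives > 50000 nM, also a limit.

None of the three measured compounds therefore has a number in this assay; each only reaches the edge of what the assay can report. Compound 1 and compound 2 share one core and differ in a single place: 3,5-dimethylphenyl in place of 2,5-dimethylphenyl on an aromatic nitrogen. The size of that step, a step that the two limits leave unreadable from compound 1 to compound 2, cannot be read, as both compounds sit at the limit of > 50000 nM in this assay, at which 3 of the 3 values shown sit. Compound 3 carries a different core from compound 1; the difference between the two cores is not broken down here.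

Compound 4, `Cc1cc(C)cc(-n2nncc2CN2C(=O)C3(C(C#N)=C(N)Oc4c(N)cc5nc6ccccc6nc5c43)c3ccccc32)c1`, has not yet been measured. It differs from compound 3 by 3,5-dimethylphenyl in place of 2,5-dimethylphenyl on an aromatic nitrogen. The place of this change is described in exactly the same words as the change from compound 1 to compound 2, so the two changes are the same change, applied on the two different cores.

Given that a step that the two limits leave unreadable from compound 1 to compound 2 could not be read and that compound 3 itself sits at the limit, the step from compound 3 to compound 4 is expected to be essentially nil, a number no higher from compound 3 to compound 4 (the limit leaves the size open). Compound 4 is accordingly expected to come out at about 50000 nM, and most likely to be reported once more only as a limit rather than as a number.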

Compound 4, half-maximal inhibitory concentration: > 50000 nM
Compound 4: no number, only a limit (the forecaster's own chance of this, stated with the estimate: 85%); the middle value sits exactly at the limit.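

The step from compound 3 to compound 4 cannot be read, as both compounds reach the same edge of what this assay can report: the limit of > 50000 nM in this assay, at which 4 of the 4 values shown sit.

The compounds shown leave open how strongly any of them actually inhibits these cells, and whether 3,5-dimethylphenyl in place of 2,5-dimethylphenyl changes the activity at all on either core.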